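The source may report more compounds than this note shows. Statements on the series, on what has been measured and on what is new or still open speak of the compounds shown alone.

Measured so far:
Compound 1 (`C=CC(=O)N1C(=O)CCSc2ccccc21`) gives 565000 nM in a functional assay on MOLT-4 cells (Homo sapiens) for cytotoxicity, read by CCK-8 assay, with a stated time of 24 h; on this read-out higher numbers stand for weaker inhibition and lower numbers for stronger inhibition
Compound 2 (`C=CC(=O)N1C(=O)CC(c2ccc(C(=O)OC)cc2)Sc2ccccc21`) gives 79600 nM in this assay

Compound 2 holds the lower of the two numbers, and its gap to compound 1 lies beyond the usual scatter. For the measured compounds named here, with only two values in hand, no trend across the series can be stated.

Compound 3 (`C=CC(=O)N1C(=O)CC(c2ccc(C#N)cc2)Sc2ccccc21`) comes from compound 2 by a single exchange (cyano in place of methoxycarbonyl on an aromatic carbon) with cyano in place of methoxycarbonyl on an aromatic carbon, para to a large group. Going by the values given here, no measured pair covers this exchange, so the expectation rests on compound 2 at 79600 nM and has no measured step to lean on. In this assay the step of a 1.1-fold lower number from compound 2 to compound 3 (0.06 log units; within the scatter) is expected to stay within the usual scatter, with no firm direction. The range is kept wide, since the evidence is so thin. For compound 3 the estimated value is 70000 nM (expected range 25000 nM to 200000 nM).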

Compound 3, half-maximal inhibitory concentration: 88700 nM
For compound 3 the middle estimate is 1.3-fold (0.10 log units) below the measured one; measured number inside the range.
By their numbers in this assay, from the lowest: compounds 2 and 3 (each within the scatter of the next); then compound 1.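

In this assay, the exchange of methoxycarbonyl for cyano on an aromatic carbon, para to a large group, reads as a 1.1-fold higher number from compound 2 to compound 3 (0.05 log units; within the scatter), so this place accepts a group of 2 heavy atoms in place of one of 4 without a readable shift. The comparison with the unsubstituted core adds a second point: 4-cyanophenyl in place of hydrogen on a saturated ring carbon gives a 6.4-fold lower number from compound 1 to compound 3 (0.80 log units; beyond the scatter), which shows that the gap from compound 1 is not confined to the methoxycarbonyl-bearing compound 2. No measured data are at hand to explain either step.

The two groups shown on the aromatic carbon leave open whether the value responds to that group at all, and an amine, a carboxylic acid or a plain hydrogen at this place would help to settle it. Going by these compounds, whether the gap from compound 1 carries over to other cell lines also stays open, with this assay as the only read-out in hand.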